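This account rests on a few compounds, and the source may have more. Where it says the series, first, only, none or still open, it means among the compounds named here.

Compound 1 `COc1ccc2c(/C=C(\C#N)C(=O)c3c[nH]c4cc(F)ccc34)c[nH]c2c1` carries a methoxy group on its indole half. In a functional assay on A549 cells (Homo sapiens) for cytotoxicity, read by WST assay, with a stated time of 24 h (on this read-out lower numbers stand for stronger inhibition and higher numbers for weaker inhibition), compound 1 gives 10300 nM. Compound 2 `N#C/C(=C\c1c[nH]c2cc(F)ccc12)C(=O)c1c[nH]c2cc(F)ccc12` is the same molecule with that methoxy group exchanged for a fluorine atom, which is the change (fluoro in place of methoxy on an aromatic carbon). For compound 2 this assay reports only > 50000 nM, and this is a limit of the assay rather than a number. The step is therefore an at least 4.8-fold higher number from compound 1 to compound 2 (0.68 log units; beyond the scatter), and its size can only be given as a lower bound because of the limit of > 50000 nM in this assay, at which 1 of the 3 values shown sits.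

Compound 3 `COc1ccc(Cn2cc(/C=C(\C#N)C(=O)c3c[nH]c4cc(OC)ccc34)c3ccccc32)cc1` has a different core, carrying a benzyl group on the indole nitrogen; how its core differs from that of compound 1 is not broken down here. In this assay compound 3 gives 37400 nM, a weaker inhibition than compound 1.

Compound 4 `COc1ccc(Cn2cc(/C=C(\C#N)C(=O)c3c[nH]c4cc(F)ccc34)c3ccccc32)cc1` has not yet been measured. It stands to compound 3 as compound 2 stands to compound 1: the change fluoro in place of methoxy on an aromatic carbon is made at the same place, so it is the same change seen once already. On the strength of that earlier step, the expected step here is a 3.2-fold higher number from compound 3 to compound 4 (0.51 log units; beyond the scatter). Since compound 3 already sits close to the limit, the estimate for compound 4 is 120000 nM, expected to fall between 40000 nM and 400000 nM, and most likely to be reported only as a limit.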

Compound 4, half-maximal inhibitory concentration: > 50000 nM
Compound 4: a limit, no number; the forecaster's own chance of this, stated with the estimate: 75%; the middle value does not contradict the limit.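

Compound 4 is reported in this assay only as > 50000 nM, which is a limit of the assay and not a number. Exchanging methoxy for fluoro on the core of compound 3 therefore gives an at least 1.3-fold higher number from compound 3 to compound 4 (0.12 log units; that floor lies within the scatter), and this floor alone does not establish a real loss of activity on this core, although the result fits the direction seen on the core of compound 1, where the step's floor lies beyond the usual scatter. What the pair of steps shows is that neither core gives any sign of the fluoro compound being the stronger inhibitor, but it does not show that the change has the same size on both cores: the same change on two cores in this assay, an at least 4.8-fold higher number (0.68 log units; beyond the scatter) from compound 1 to compound 2 and an at least 1.3-fold higher number (0.12 log units; that floor lies within the scatter) from compound 3 to compound 4; the limit leaves it open whether they differ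

As far as these compounds go, the real values of compound 2 and compound 4 remain unknown, so neither step has an upper end, and the comparison between the two cores stays unsettled. Also open is how this series responds to other groups at this place on the aromatic ring, such as an amine, a carboxylic acid or a longer chain like ethoxy, since only methoxy and fluoro appear there among the compounds shown.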